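Adding a chloro group to a well-tolerated shared core

This account rests on a few compounds, and the source may have more. Where it says the series, first, only, none or still open, it means among the compounds named here.

Compound 1, `O[C@@H]1Cc2ccccc2N[C@H](c2ccccc2Cl)C1`, and compound 2, `O[C@@H]1Cc2ccccc2N[C@H](c2ccccc2F)C1`, share one core and differ only in the halogen on the pendant aromatic ring. In an ADME assay on Vero cells (Chlorocebus sabaeus) for cytotoxicity, read by MTT assay, with a stated time of 72 h (a lower number here means that less compound is tolerated, a higher number that more compound is tolerated), compound 1 gives > 300000 nM, which is a limit of the assay rather than a number. In this assay compound 2 likewise gives > 300000 nM, again a limit. The change from compound 1 to compound 2 is fluoro in place of chloro on an aromatic carbon, and the step that the two limits leave unreadable from compound 1 to compound 2 cannot be sized because of the limit of > 300000 nM in this assay, at which 2 of the 2 values shown sit. Among the measured compounds shown here, compound 2 therefore stands at the same limit as the only other compound measured.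

Compound 3, `O[C@@H]1Cc2cc(Cl)ccc2N[C@H](c2ccccc2F)C1`, differs from compound 2 by chloro in place of hydrogen on an aromatic carbon. For the measured compounds named here, no measured step is readable, so there is nothing to point to a shift in either direction; the only guide is that both measured compounds sit at the limit. Compound 3 is expected to behave the same way, with an estimated 300000 nM, in a range from 150000 nM to 300000 nM, meaning an expected step of a number no higher from compound 2 to compound 3 (the limit leaves the size open), most likely reported as a limit again.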

Compound 3, half-maximal cytotoxic concentration: 182000 nM
Estimate against measurement, compound 3: 1.6-fold (0.22 log units) above; the measured number falls inside the stated range.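

Among the compounds shown here, compound 3 is the first compound here to give a measured number rather than a limit, so this aromatic carbon, meta to a fused ring and para to a fused ring, is the first place where a change yields a readable value in this assay. Chloro in place of hydrogen at this position also gives the first step with a stated direction (an at least 1.6-fold lower number from compound 2 to compound 3 (0.21 log units; that floor lies within the scatter)), although that step has only a floor, and the floor alone does not establish a real drop in tolerance. On these data alone, the full size of the step stays open because compound 2 sits at a limit, not at a number: (the limit of > 300000 nM in this assay, at which 2 of the 3 values shown sit).

As far as these compounds go, it remains open whether the number at this position depends on chloro itself or whether another group there, such as a methyl, an amine or a carboxylic acid, would give a similar value in this assay. From the compounds shown here alone, it is also open whether the same chloro would give a similar result with chloro rather than fluoro on the pendant ring, as in compound 1.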